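Replacing a methyl with fluoro on a fused chromanone core

The compounds below may be only part of what the source reports. "The series", "measured", "known", "first", "only" and "open" are said of these compounds alone.

Of the compounds shown here, three have been measured in an in vitro assay on BTI-TN-5B1-4 cells for inhibition of Amine oxidase [flavin-containing] B (Homo sapiens); a lower number here means a stronger inhibitor, a higher number a weaker inhibitor. Compound 1 `Cc1ccc([C@H]2CC(=O)c3ccc(F)cc3O2)cc1` gives 150 nM in this assay. Compound 2 `Cc1ccc([C@H]2CC(=O)c3ccc(C)cc3O2)cc1` gives 530 nM. Compound 3 `Cc1ccc2c(c1)OC(c1ccc(F)cc1)CC2=O` gives 130 nM; against compound 1 the two numbers lie within the scatter, while the gap to compound 2 lies beyond it.

Compound 1 and compound 2 differ in one place: fluoro in place of methyl on an aromatic carbon. That change gave a 3.5-fold lower number from compound 2 to compound 1 (0.55 log units; beyond the scatter). The cores of compound 2 and compound 3 also differ, but that difference is not broken down here.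

Compound 4 `O=C1CC(c2ccc(F)cc2)Oc2cc(F)ccc21` has not yet been measured. It arises from compound 3 by the same change, at a place described in the same words: fluoro in place of methyl on an aromatic carbon. Since the earlier example of this change, from compound 2 to compound 1, was a modest step beyond the scatter, a step of similar size is expected here, so that compound 4 is estimated at a 2.9-fold lower number from compound 3 to compound 4 (0.46 log units; beyond the scatter) in this assay. The expected value for compound 4 is therefore 45 nM, with a likely range from 15 nM to 130 nM.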

Compound 4, half-maximal inhibitory concentration: 670 nM
Compound 4: the middle estimate sits 15-fold (1.17 log units) below what was measured, outside the stated range (above it).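

On the second core, fluoro in place of methyl on an aromatic carbon gave a 5.2-fold higher number from compound 3 to compound 4 (0.71 log units; beyond the scatter) in this assay, so the same swap that strengthened inhibition on the first core weakened it here. Set side by side, the two results differ in direction, and the gap between them is larger than repeated measurements would explain, so the step seen on one core cannot simply be carried over to the other: the same change on two cores in this assay, a 3.5-fold lower number (0.55 log units; beyond the scatter) from compound 2 to compound 1 and a 5.2-fold higher number (0.71 log units; beyond the scatter) from compound 3 to compound 4, 18-fold (1.26 log units) apart, beyond the scatter of two such steps. This shows that, for these two pairs, the result of the swap depends on the core, but it does not show which feature of the cores turns the step around, nor how the swap would behave on any other core.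

As far as these compounds go, it remains open whether a chloro or a methoxy group in that same place would follow the first step, the second, or neither. Also open, from the compounds shown here alone, is which of the two steps, if either, would be repeated on a third core bearing a methyl at that place.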